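This account rests on a few compounds, and the source may have more. Where it says the series, first, only, none or still open, it means among the compounds named here.

Among the compounds with values here, compound 2 `CNCc1cccc(/C=N\Nc2ncnc3sc(C(C)(C)C)cc23)n1` stands highest of the two numbers so far in a functional assay on PC-6 cells (Homo sapiens) for antiproliferative activity; on this read-out higher numbers stand for weaker inhibition and lower numbers for stronger inhibition: compound 2 gives 0.189 ug/mL, while compound 1 `CC(C)(C)c1cc2c(N/N=C\c3ccccn3)ncnc2s1` gives 0.009 ug/mL. Within the data shown here, the only measured step is a 21-fold higher number from compound 1 to compound 2 (1.32 log units; beyond the scatter), in which a (methylamino)methyl group enters on an aromatic carbon. Compound 3 `CN(C)Cc1cccc(/C=N\Nc2ncnc3sc(C(C)(C)C)cc23)n1` differs from compound 2 by methyl in place of hydrogen on an amine nitrogen. Among the measured compounds shown here, no measured step bears directly on this change: the whole group entering in the step from compound 1 to compound 2 is not the same thing as a single methyl added at the amine nitrogen of a group that is already present, so that step gives no guide to direction here. The expectation for compound 3 in this assay is therefore no step beyond the scatter, with the chance of a modest movement either way. Compound 3 is estimated at 0.2 ug/mL, with a range from 0.07 ug/mL to 0.6 ug/mL, which corresponds to an expected step of a 1.1-fold higher number from compound 2 to compound 3 (0.02 log units; within the scatter).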

Compound 3, half-maximal inhibitory concentration: 0.381 ug/mL
Beside the measured number, compound 3's estimate is 1.9-fold (0.28 log units) below it, within the range that was stated.
By their numbers in this assay, from the lowest: compound 1; then compounds 2 and 3 (each within the scatter of the next).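

In this assay, methyl on the amine nitrogen gives a 2.0-fold higher number from compound 2 to compound 3 (0.30 log units; within the scatter), so going from methylamino to dimethylamino shows no effect that can be told from the scatter. The large gap to the unsubstituted compound also holds with the (dimethylamino)methyl group, which gives a 42-fold higher number from compound 1 to compound 3 (1.63 log units; beyond the scatter) and so shows that the gap seen with the (methylamino)methyl group is not confined to that one amine. No supporting data bear on the origin of either step.

On these data alone, it remains open whether the gap to compound 1 follows the amine nitrogen or any group on that aromatic carbon: an aminomethyl, a hydroxymethyl or a plain methyl group there would separate the two. As far as these compounds go, how a larger amine such as piperidine or morpholine would compare with compound 2 and compound 3 also remains open.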